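The source may report more compounds than this note shows. Statements on the series, on what has been measured and on what is new or still open speak of the compounds shown alone.

Working notes on the series.

Compound 1 `CCc1cc(C)c(C(=O)N=C(N)N)cc1S(C)(=O)=O` gives 4.8 nM in a functional assay for inhibition of sodium/hydrogen exchanger (Oryctolagus cuniculus); on this read-out higher numbers stand for weaker inhibition and lower numbers for stronger inhibition. Among the compounds with values here, compound 2 `Cc1cc(N2CCCC(O)C2)c(S(C)(=O)=O)cc1C(=O)N=C(N)N` gives 30 nM in this assay; the step of a 6.3-fold higher number from compound 1 to compound 2 (0.80 log units; beyond the scatter) is the only measured step, and on it compound 2 has the higher number of the two.

Compound 3 `Cc1cc(-n2cccn2)c(S(C)(=O)=O)cc1C(=O)N=C(N)N` is not yet measured. Its difference from compound 2 is 1H-pyrazol-1-yl in place of 3-hydroxypiperidin-1-yl on an aromatic carbon. Within the data shown here, the single step that bears on this position is a 6.3-fold higher number from compound 1 to compound 2 (0.80 log units; beyond the scatter), which shows that the group on this aromatic carbon moves this assay by a modest amount. The new group shares no feature with either of the two measured groups, so direction is not fixed by the data. Compound 3 is expected to fall near the two measured values, with the estimated step of a 2.0-fold lower number from compound 2 to compound 3 (0.30 log units; within the scatter) lying within or close to the scatter. The estimate for compound 3 in this assay is 15 nM, range 4 nM to 60 nM.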

Compound 3, half-maximal inhibitory concentration: 25 nM
For compound 3 the middle estimate is 1.7-fold (0.22 log units) below the measured one, within the range that was stated.
By their numbers in this assay, from the lowest: compound 1; then compounds 3 and 2 (each within the scatter of the next).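

Working from this assay, the change a 1.2-fold lower number from compound 2 to compound 3 (0.08 log units; within the scatter) shows that a five-membered aromatic ring with 2 hetero atoms and a six-membered non-aromatic ring carrying a hydroxyl cannot be told apart on this aromatic carbon, ortho to the methylsulfonyl group. The entering group has no hydrogen-bond donor, so a donor on this group is not needed to hold the number at this level. Ethyl now stands apart from a second ring substituent, with a 5.2-fold higher number from compound 1 to compound 3 (0.72 log units; beyond the scatter) beyond the scatter, and both ring-bearing compounds lie on the same side of compound 1.

No measurement on hand explains the gap between ethyl and the two rings. Open, as far as these compounds go, is whether a propyl chain or a dimethylamino group at this carbon would stay close to ethyl or join the two rings, and whether a phenyl ring would behave like 1H-pyrazol-1-yl.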